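A few compounds are considered here, and "the series" means these few. Any claim that something is new, unique, unknown or untested is made for them only; others in the source may bear on it.

Measured compounds:
compound 1, `COc1ccc(C(=O)O[C@H]2CC(C)=C[C@H](O)[C@@]3(C)[C@@H](OC(C)=O)C[C@@](O)(C(C)C)[C@H]23)cc1`: 48200 nM
compound 2, `CC1=CC[C@]2(C)[C@@H]([C@@H](OC(=O)c3ccc(O)cc3)C1)[C@](O)(C(C)C)C[C@@H]2O`: 95000 nM
compound 3, `COc1ccc(C(=O)O[C@H]2CC(C)=CC[C@@]3(C)CC[C@@](O)(C(C)C)[C@H]23)cc1`: 67800 nM

All three were tested in a functional assay on K562 cells (Homo sapiens) for cytotoxicity, read by MTT assay, with a stated time of 72 h; on this read-out higher numbers stand for weaker inhibition and lower numbers for stronger inhibition. Among them compound 1 has the lowest number, but its gap to compound 3 and its gap to compound 2 both sit within the usual scatter of such measurements, so none of the three can be called stronger or weaker than another on this evidence.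

The step considered here leads from compound 1 to compound 4, whose structure is `COc1ccc(C(=O)O[C@H]2CC(C)=C[C@@H](O)[C@@]3(C)[C@@H](OC(C)=O)C[C@@](O)(C(C)C)[C@H]23)cc1`. The change is: the two compounds have the same atoms and bonds and differ only in configuration as drawn: 1 of 6 stereo elements differ; a stereocentre at a saturated ring carbon is drawn S in compound 1 and R in compound 4. Nothing enters or leaves; only the drawn arrangement at one saturated ring carbon is flipped.

Within the data shown here, no pair of measured compounds differs in a single place, so there is no measured step to guide the expectation. A flip at one ring stereocentre in a compound with weak activity is expected to move the number by no more than the scatter, with no clear direction, so the expected step from compound 1 to compound 4 is a 1.1-fold higher number from compound 1 to compound 4 (0.06 log units; within the scatter). Compound 4 is thus estimated at 55000 nM, with a range from 20000 nM to 150000 nM.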

Compound 4, half-maximal inhibitory concentration: 85200 nM
Estimate against measurement, compound 4: 1.5-fold (0.19 log units) below; the range from low to high includes it.
By their numbers in this assay, from the lowest: compounds 1, 3, 4 and 2 (each within the scatter of the next).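

Among these compounds, compounds 1 and 4 form the first pair in this set that can be read as a single change, and the comparison rests on one point: the fact that compounds 1 and 4 differ only in the configuration as drawn. In this assay, flipping the saturated ring carbon gives a 1.8-fold higher number from compound 1 to compound 4 (0.25 log units; within the scatter). On this evidence, the drawn arrangement at this one carbon has no effect that can be told apart from the ordinary spread of repeated measurements, so either arrangement fits with the numbers seen so far.

Going by these compounds, it remains open whether a different group on the shared core, such as an amine or a carboxylic acid, would give a number clearly apart from these. On these data alone, it is also open whether the same flip would have a larger effect in a compound with a much lower number.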